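The compounds below may be only part of what the source reports. "The series", "measured", "known", "first", "only" and "open" are said of these compounds alone.

In a functional assay on HeLa S3 cells (Homo sapiens) for cytotoxicity, read by XTT assay, with a stated time of 3 days (a higher number here means a weaker inhibitor, a lower number a stronger inhibitor), three compounds have been measured. Compound 1 `OC[C@H]1O[C@@H](n2cc(F)c3c(-c4ccccc4)ncnc32)[C@H](O)[C@@H]1O` gives 2600 nM. Compound 2 `OC[C@H]1O[C@@H](n2cc(F)c3c(-c4cccs4)ncnc32)[C@H](O)[C@@H]1O` gives 4300 nM. Compound 3 `OC[C@H]1O[C@@H](n2cc(F)c3c(-c4nccs4)ncnc32)[C@H](O)[C@@H]1O` gives 3100 nM.

Compound 3 stands second highest of the three numbers, with compound 1 nearest and compound 2 furthest, yet all three values lie within the usual scatter of one another, so no order among them can be claimed. Compound 4 `OC[C@H]1O[C@@H](n2cc(F)c3c(-c4cc[nH]c4)ncnc32)[C@H](O)[C@@H]1O` differs from compound 3 in one place: 1H-pyrrol-3-yl in place of 1,3-thiazol-2-yl on an aromatic carbon. Among the measured compounds shown here, the steps that bear on this exchange of one five-membered ring for another are a 1.4-fold lower number from compound 2 to compound 3 (0.14 log units; within the scatter) and a 1.2-fold higher number from compound 1 to compound 3 (0.08 log units; within the scatter), together with a 1.7-fold higher number from compound 1 to compound 2 (0.22 log units; within the scatter); none moved the number beyond the scatter. A step of similar size, in no set direction, is therefore expected: a 1.0-fold lower number from compound 3 to compound 4 (0.01 log units; within the scatter). Compound 4 is estimated at 3000 nM, with a range from 1200 nM to 8000 nM.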

Compound 4, half-maximal inhibitory concentration: 8900 nM
For compound 4 the middle estimate is 3.0-fold (0.47 log units) below the measured one; the whole stated range lies below it.
By their numbers in this assay, from the lowest: compounds 1, 3 and 2 (each within the scatter of the next); then compound 4.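

In this assay the group on this aromatic carbon turns out to matter: 1H-pyrrol-3-yl, which brings in a hydrogen-bond donor, gives a 2.9-fold higher number from compound 3 to compound 4 (0.46 log units; beyond the scatter) and a 2.1-fold higher number from compound 2 to compound 4 (0.32 log units; beyond the scatter) and a 3.4-fold higher number from compound 1 to compound 4 (0.53 log units; beyond the scatter) and each of these steps lies beyond the scatter. The exchanges among phenyl, thiophen-2-yl and 1,3-thiazol-2-yl all stayed within it, so this position does respond to a change of ring, though only modestly in these compounds.

As far as these compounds go, how a phenyl ring carrying an amine or a hydroxyl would compare remains open. Nothing measured here accounts for the step.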